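The compounds below may be only part of what the source reports. "The series", "measured", "known", "first", "only" and "open" are said of these compounds alone.

Going by the values given here, compound 2 `O=C(NCc1ccccc1)c1cncc(N2CC3CC(C2)N3)c1` carries a benzyl on the amide-type nitrogen of the shared core; in an assay on membranes from Cerebral cortex for displacement of a labelled ligand from Neuronal acetylcholine receptor; alpha4/beta2 (Rattus norvegicus) (a higher number here means a weaker inhibitor, a lower number a stronger inhibitor), compound 2 gives 1.8 nM, the highest of the two numbers measured so far. Compound 1 `O=C(Nc1ccc(F)cc1)c1cncc(N2CC3CC(C2)N3)c1` carries 4-fluorophenyl in that place, and in this assay compound 1 gives 0.01 nM. Among the compounds with values here, the single measured step, a 180-fold higher number from compound 1 to compound 2 (2.26 log units; beyond the scatter), shows how strongly this nitrogen substituent governs the number. Compound 3 `O=C(Nc1cccc(F)c1)c1cncc(N2CC3CC(C2)N3)c1` differs from compound 2 as follows: 3-fluorophenyl in place of benzyl on an amide-type nitrogen. This is essentially the reverse of the measured step, with a differently placed fluorine; no measurement separates 3-fluorophenyl from 4-fluorophenyl, so that part of the change has no guide. For compound 3 a large fall in this assay is expected, a 45-fold lower number from compound 2 to compound 3 (1.65 log units; beyond the scatter), recovering most of the measured step. The estimate for compound 3 in this assay is 0.04 nM, expected between 0.005 nM and 0.4 nM.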

Compound 3, inhibition constant: 0.044 nM
Compound 3: middle estimate off by 1.1-fold (0.04 log units), on the low side; low and high end bracket the measured number.
By their numbers in this assay, from the lowest: compound 1; then compound 3; then compound 2.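

With 3-fluorophenyl on the amide-type nitrogen, a 41-fold lower number from compound 2 to compound 3 (1.61 log units; beyond the scatter) in this assay shows that the large gain over benzyl does not depend on 4-fluorophenyl alone. The place of the fluorine still counts: a 4.4-fold higher number from compound 1 to compound 3 (0.64 log units; beyond the scatter) is a modest step but lies beyond the scatter, and it is clearly smaller than the step from benzyl. No evidence is available to explain either step.

Whether the fluorine itself contributes, or the directly attached phenyl accounts for the gain, remains open, as does the effect of 2-fluorophenyl on this nitrogen. Also open, from the compounds shown here alone, is how a methoxy-substituted phenyl or a longer chain such as phenethyl would compare with benzyl and the two fluorophenyl groups in this assay on the shared core.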